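The compounds below may be only part of what the source reports. "The series", "measured", "known", "first", "only" and "open" are said of these compounds alone.

Measured compounds in an ADME assay on HaCaT cells (Homo sapiens) for antiproliferative activity, read by MTT assay, with a stated time of 48 h; on this read-out higher numbers stand for weaker inhibition and lower numbers for stronger inhibition:
compound 1, `O=C(/C=C\Nc1ccc(Cl)cc1)c1cn(-c2ccccc2)nc1-c1ccccc1`, gives 28400 nM.
compound 2, `COc1ccc(N/C=C\C(=O)c2cn(-c3ccccc3)nc2-c2ccccc2)cc1`, gives > 50000 nM, which is a limit of the assay and not a number.
compound 3, `O=C(/C=C\Nc1ccc(F)cc1)c1cn(-c2ccccc2)nc1-c1ccc(Cl)cc1`, gives > 50000 nM, which is a limit of the assay and not a number.

Compound 1 and compound 2 differ in one place: methoxy in place of chloro on an aromatic carbon. In this assay the step is an at least 1.7-fold higher number from compound 1 to compound 2 (0.24 log units; that floor lies within the scatter). Its true size is open-ended due to the limit of > 50000 nM in this assay, at which 2 of the 3 values shown sit.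

Compound 3 shares this arrangement of a chloro group with compound 1, but the difference between the two cores is not broken down here. Compound 4, `COc1ccc(-c2nn(-c3ccccc3)cc2C(=O)/C=C\Nc2ccc(F)cc2)cc1`, has not yet been measured; it stands to compound 3 as compound 2 stands to compound 1: methoxy in place of chloro on an aromatic carbon. The place of the change is described in the same words for both pairs. Read one bond further out, the change in the earlier pair also covers (4-chlorophenyl)amino to (4-methoxyphenyl)amino, whereas for compound 3 to compound 4 it reads only 4-chlorophenyl to 4-methoxyphenyl, so the two are taken as the same change at the counted place.

Compound 3 sits at a limit in this assay, so a step of the earlier kind cannot be resolved here. Compound 4 is expected to remain at a limit as well, with an estimate of 70000 nM in this assay. The expected step is a step that the limit leaves unreadable from compound 3 to compound 4, set beside the earlier one. This rests on compound 3 giving > 50000 nM, a limit. The estimate for compound 4 spans 40000 nM to 150000 nM.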

Compound 4, half-maximal inhibitory concentration: 8910 nM
Compound 4: the middle estimate sits 7.9-fold (0.90 log units) above what was measured; measured number below the stated range.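

In this assay the change from chloro to methoxy, read on the core of compound 3, gives an at least 5.6-fold lower number from compound 3 to compound 4 (0.74 log units; beyond the scatter), so here methoxy goes with the stronger inhibition. The change therefore does not carry over from one core to the other with a constant size, and the two steps are clearly separate: the same change on two cores in this assay, an at least 1.7-fold higher number (0.24 log units; that floor lies within the scatter) from compound 1 to compound 2 and an at least 5.6-fold lower number (0.74 log units; beyond the scatter) from compound 3 to compound 4, at least 9.8-fold (0.99 log units) apart, beyond the scatter of two such steps. This does not give the true size of either step, since each one ends at a limit, and it does not separate the influence of the core from that of the attachment, which reads (4-chlorophenyl)amino to (4-methoxyphenyl)amino in one pair and 4-chlorophenyl to 4-methoxyphenyl in the other: the limit of > 50000 nM in this assay, at which 2 of the 4 values shown sit.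

The compounds shown leave open whether the value of compound 4, 8910 nM, holds when methoxy gives way to an ethoxy group, a dimethylamino group or a carboxylic acid at the same place. Among these compounds, they also leave open how much of that value depends on the fluoro group that compound 4 carries elsewhere, as no pair here isolates that group with methoxy held in place.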